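Acetoxy and hydroxy changes on a cyclopentenone series

A few compounds are considered here, and "the series" means these few. Any claim that something is new, unique, unknown or untested is made for them only; others in the source may bear on it.

Measured so far in an ADME assay on KB cells (Homo sapiens) for cytotoxicity, read by MTT assay, with a stated time of 72 h; on this read-out higher numbers stand for weaker inhibition and lower numbers for stronger inhibition:
Compound 1 `COc1ccc(C2=C(c3cc(OC)c(OC)c(OC)c3)C(=O)C(OC(C)=O)C2)cc1` gives 72 ug/mL.
Compound 2 `COc1ccc(C2=C(c3cc(OC)c(OC)c(OC)c3)C(=O)C(O)C2)cc1` gives < 1 ug/mL, which is a limit of this assay and not a number.

Compound 1 carries the only number shown in this assay; the other value shown is a limit (the limit of < 1 ug/mL in this assay, at which 1 of the 2 values shown sits). Among the measured compounds shown here, the single measured step, an at least 72-fold lower number from compound 1 to compound 2 (1.85 log units; beyond the scatter), concerns the oxygen on a saturated carbon and not the aromatic ring.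

Compound 3 `COc1ccc(C2=C(c3cc(OC)c(OC)c(OC)c3)C(=O)C(OC(C)=O)C2)cc1O` differs from compound 1 by hydroxy in place of hydrogen on an aromatic carbon. For the measured compounds named here, no measured step bears on this change: the step from compound 1 to compound 2 exchanges acetyl for hydrogen elsewhere, so it gives no guide to a hydroxy entering an aromatic carbon. With nothing to build on, no step beyond the scatter is expected in this assay, though the estimate is held wide. Compound 3 is therefore expected at 40 ug/mL, between 5 ug/mL and 150 ug/mL, a step of a 1.8-fold lower number from compound 1 to compound 3 (0.26 log units; within the scatter).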

Compound 3, half-maximal inhibitory concentration: 35 ug/mL
Estimate against measurement, compound 3: 1.1-fold (0.06 log units) above; the measured number falls inside the stated range.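

In this assay, hydroxy in place of hydrogen on an aromatic carbon, ortho to a methoxy group, gives a 2.1-fold lower number from compound 1 to compound 3 (0.31 log units; beyond the scatter). Among the compounds shown here, this is the only reading so far on the aromatic ring, and it shows a modest step on the side of stronger inhibition, with the acetyl still in place. It is small beside an at least 72-fold lower number from compound 1 to compound 2 (1.85 log units; beyond the scatter), so among the compounds shown, the acetyl on the oxygen on a saturated carbon counts for more than this ring hydrogen.

Going by these compounds, whether the ring hydroxy would still move the number alongside the free hydroxy of compound 2 stays open, and the compound 2 value of < 1 ug/mL is a limit of the assay and not a number: the limit of < 1 ug/mL in this assay, at which 1 of the 3 values shown sits. Also open is how an amine at the same ring position, or a longer chain in place of acetyl, would read in this assay.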